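Changing the group on the five-membered aromatic ring

A few compounds are considered here, and "the series" means these few. Any claim that something is new, unique, unknown or untested is made for them only; others in the source may bear on it.

Measured so far:
Compound 1, `c1ccc(-c2ccc(OCc3nnc(-c4ccccc4)o3)cc2)cc1`: 18.2%
Compound 2, `Clc1ccc(-c2nnc(COc3ccc(-c4ccccc4)cc3)o2)c(Cl)c1`: 57.6%

In a functional assay on the whole organism (strain Wistar) for inhibition, with Rattus norvegicus as the target, read by paw edema, with a stated time of 4 h, at a dose of 10 mg/kg by the oral route (a higher number here means more inhibition at the dose given (going by the name of the read-out), a lower number less inhibition), compound 2 gives 57.6%, the higher of the two numbers, and compound 1 gives 18.2%. Among the measured compounds shown here, the one measured step is a number 39.4 percentage points higher from compound 1 to compound 2 (beyond the scatter), a change at the same aromatic carbon of the shared core.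

Compound 3, `Fc1ccc(Nc2nnc(COc3ccc(-c4ccccc4)cc3)o2)cc1`, has not been measured. It differs from compound 2 in one place: (4-fluorophenyl)amino in place of 2,4-dichlorophenyl on an aromatic carbon. The measured step bears on this only indirectly, since the entering group has not been tested at this carbon; what it does show, through a number 39.4 percentage points higher from compound 1 to compound 2 (beyond the scatter), is that the read-out can move widely when this group changes. For the measured compounds named here, with no direct precedent, a fall back toward the middle of the measured range seems the likelier outcome, with wide uncertainty. Compound 3 is therefore estimated at 35%, ranging from 15% to 58%. This estimate amounts to an expected step of a number 22.6 percentage points lower from compound 2 to compound 3 (beyond the scatter).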

Compound 3, a percentage reported as inhibition, in the whole organism at one dose (the size of the read-out at that dose, not a potency): 52.3%
Compound 3: middle estimate off by 17.3 percentage points, on the low side; measured number inside the range.
By their numbers in this assay, from the lowest: compound 1; then compounds 3 and 2 (each within the scatter of the next).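

In this assay, among the compounds shown here, (4-fluorophenyl)amino in place of phenyl on this carbon of the five-membered aromatic ring gives a number 34.1 percentage points higher from compound 1 to compound 3 (beyond the scatter) and shows that 2,4-dichlorophenyl is not the only group here that stands clear of plain phenyl. Set against 2,4-dichlorophenyl, the same group gives a number 5.3 percentage points lower from compound 2 to compound 3 (within the scatter) and so cannot be told apart from it in this test, even though only the entering group has the amino link, with its hydrogen-bond donor and acceptor. Nothing available explains why two such different groups read alike.

On these data alone, it remains open whether the amino link, the fluorine or both account for the difference from compound 1. A plain phenylamino group and a 4-fluorophenyl group joined directly to this carbon would help separate those two parts.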